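The source may report more compounds than this note shows. Statements on the series, on what has been measured and on what is new or still open speak of the compounds shown alone.

In a functional assay on ECa-109 cells for inhibition, with ECa-109 cell line (Homo sapiens) as the target, read by sulforhodamine B assay (a higher number here means a weaker inhibitor, a lower number a stronger inhibitor), three compounds sharing one core have been measured. Compound 1 `O=C1C=C(N2CCC2)C(=O)c2c1nc1n2[C@H]2OC[C@@H](O)[C@H]2OC1`, which carries azetidin-1-yl, reads > 16000 nM, and this value is a limit of the assay, not a number. Compound 3 `CCc1ccc(NC2=CC(=O)c3nc4n(c3C2=O)[C@H]2OC[C@@H](O)[C@H]2OC4)cc1`, with (4-ethylphenyl)amino at that place, gives 3080 nM. Compound 2 `O=C1C=C(Nc2ccccc2F)C(=O)c2c1nc1n2[C@H]2OC[C@@H](O)[C@H]2OC1`, with (2-fluorophenyl)amino, gives 2760 nM, so the two stand level. Replacing azetidin-1-yl produced clear steps: an at least 5.7-fold lower number from compound 1 to compound 2 (0.76 log units; beyond the scatter) and an at least 5.1-fold lower number from compound 1 to compound 3 (0.71 log units; beyond the scatter).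

Compound 4 `O=C1C=C(Nc2ccc(Br)cc2)C(=O)c2c1nc1n2[C@H]2OC[C@@H](O)[C@H]2OC1` has bromo in place of ethyl on an aromatic carbon, para to a large group: bromo in place of ethyl on an aromatic carbon. Its (4-bromophenyl)amino group therefore keeps the phenylamino link and alters only the ring substituent. Going by the values given here, the closest precedent is the exchange of one substituted phenyl for another, a 1.1-fold higher number from compound 2 to compound 3 (0.05 log units; within the scatter), which stays within the scatter. The much larger steps from compound 1 replace the whole group and bear less directly on this change. No step beyond the scatter is therefore expected, and the estimated step is a 1.1-fold lower number from compound 3 to compound 4 (0.04 log units; within the scatter). For compound 4, the estimate is 2800 nM, with an expected range from 1200 nM to 6500 nM.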

Compound 4, half-maximal inhibitory concentration: 2850 nM
Beside the measured number, compound 4's estimate is 1.0-fold (0.01 log units) below it; measured number inside the range.
By their numbers in this assay, from the lowest: compounds 2, 4 and 3 (each within the scatter of the next). At a limit, above all of these: compound 1.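

In this assay, bromo in place of ethyl on an aromatic carbon, para to a large group, leaves the two compounds level: a 1.1-fold lower number from compound 3 to compound 4 (0.03 log units; within the scatter). A third substituted phenyl also stands level with the fluorinated one, with a 1.0-fold higher number from compound 2 to compound 4 (0.01 log units; within the scatter), while replacing azetidin-1-yl with (4-bromophenyl)amino gives an at least 5.6-fold lower number from compound 1 to compound 4 (0.74 log units; beyond the scatter), the third step of this kind beyond the scatter. As far as these compounds go, compound 1 reads > 16000 nM, which is a limit and not a number, so the full size of these steps stays unknown: the limit of > 16000 nM in this assay, at which 1 of the 4 values shown sits.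

From the compounds shown here alone, it remains open whether a phenyl ring carrying a hydroxyl, an amine or a carboxylic acid would also stand level with these three. Also open, going by these compounds, is how a benzylamino group or a longer open-chain amine would read at this position.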